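Compound 4: a halogen swap on a bis-benzylidene core

This account rests on a few compounds, and the source may have more. Where it says the series, first, only, none or still open, it means among the compounds named here.

Compound 3 `C=CCn1c(=O)/c(=C\c2ccccc2Cl)[nH]c(=O)/c1=C\c1ccccc1OC` gives 2500 nM in a functional assay on K562 cells (Homo sapiens) for cytotoxicity, read by CCK-8 assay, with a stated time of 72 h; a higher number here means a weaker inhibitor, a lower number a stronger inhibitor. Its nearest neighbour is compound 1 `COc1ccccc1/C=c1/[nH]c(=O)/c(=C\c2ccccc2OC)n(C)c1=O`, which gives 2200 nM in this assay; the two values lie within the scatter of each other, so nothing separates them. Compound 2 `COc1ccccc1/C=c1/[nH]c(=O)/c(=C\c2cccc(Cl)c2Cl)[nH]c1=O` was reported as "not active" (no number reported) in this assay, without a number. Compound 4 `C=CCn1c(=O)/c(=C\c2cc(Br)ccc2F)[nH]c(=O)/c1=C\c1ccccc1OC` differs from compound 3 only by 5-bromo-2-fluorophenyl in place of 2-chlorophenyl on a double-bonded chain carbon bound to an aromatic carbon. Within the data shown here, no measured pair shows this change on its own, so the size of the step is open; the account expects no shift in this assay beyond the scatter, with the downside that a halogen-rich ring might follow compound 2 into inactivity. For compound 4 the estimate is 3000 nM (range 1200 nM to 8000 nM), a step of a 1.2-fold higher number from compound 3 to compound 4 (0.08 log units; within the scatter).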

Compound 4, half-maximal inhibitory concentration: 5100 nM
The estimate for compound 4 lay 1.7-fold (0.23 log units) below the measured number; the measured number falls inside the stated range.
By their numbers in this assay, from the lowest: compounds 1 and 3 (each within the scatter of the next); then compound 4.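

In this assay, among these compounds, the position on a double-bonded chain carbon bound to an aromatic carbon proves sensitive to its ring: 5-bromo-2-fluorophenyl in place of 2-chlorophenyl gives a 2.0-fold higher number from compound 3 to compound 4 (0.31 log units; beyond the scatter), a modest step and the first single-place change. The swap still leaves a measurable number, so this position tolerates the larger ring with only a modest loss. Nothing available accounts for the step.

Since the bromine and the fluorine enter together, their separate contributions remain unresolved. On these data alone, how a ring carrying an amine or a carboxylic acid would read at this place also remains open.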